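Moving a chlorine on the arylpiperazine: compound 3 to 4

The compounds below may be only part of what the source reports. "The series", "measured", "known", "first", "only" and "open" are said of these compounds alone.

Of the compounds shown here, three sharing one core have been measured in an assay on membranes from frontal cortex for displacement of a labelled ligand from Adrenergic receptor alpha-1 (Rattus norvegicus), read by scintillation counting, with a stated time of 45 min; on this read-out higher numbers stand for weaker inhibition and lower numbers for stronger inhibition. Compound 2, `CCC1(CCCCN2CCN(c3ccccc3OC)CC2)C(=O)Nc2ccccc21`, gives 27 nM in this assay. Compound 1, `CCC1(CCCCN2CCN(c3ccc(Cl)cc3)CC2)C(=O)Nc2cc(F)ccc21`, gives 215 nM. Compound 3, `CCC1(CCCCN2CCN(c3cccc(Cl)c3)CC2)C(=O)Nc2cc(F)c(Cl)cc21`, gives 117 nM, which places it second highest of the three numbers: its gap to compound 1 lies within the usual scatter, while compound 2 sits well below it, beyond the scatter.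

Compound 4 is `CCC1(CCCCN2CCN(c3ccc(Cl)cc3)CC2)C(=O)Nc2cc(F)c(Cl)cc21`. It keeps the core of compound 3 and differs only in the group on the amine nitrogen in the ring: 4-chlorophenyl in place of 3-chlorophenyl on an amine nitrogen in a ring. Going by the values given here, no measured pair in this set shows this exact change on its own, so the step carries no direct precedent. Compound 1 also carries the 4-chlorophenyl group, on a core lacking the second halogen, and its value of 215 nM is of the same order as that of compound 3. On that basis the step is expected to be small, most likely not beyond the scatter, with a 1.5-fold higher number from compound 3 to compound 4 (0.16 log units; within the scatter) as the estimate. Compound 4 is therefore expected to give about 170 nM in this assay, within a range from 70 nM to 400 nM.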

Compound 4, inhibition constant: 191 nM
The estimate for compound 4 lay 1.1-fold (0.05 log units) below the measured number, and the stated range covers the measured number.
By their numbers in this assay, from the lowest: compound 2; then compounds 3, 4 and 1 (each within the scatter of the next).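

In this assay, moving the chlorine gives a 1.6-fold higher number from compound 3 to compound 4 (0.21 log units; within the scatter), so on this core the 4-chlorophenyl and 3-chlorophenyl groups on the amine nitrogen in the ring cannot be told apart. The second new pair shows a similar result for a change elsewhere: chloro in place of hydrogen on an aromatic carbon gives a 1.1-fold lower number from compound 1 to compound 4 (0.05 log units; within the scatter), again no real difference with the 4-chlorophenyl group in place. Nothing measured here offers an explanation for either result.

Still open, as far as these compounds go, is whether a different group in place of the chlorine, such as a nitrile or a carboxylic acid, would shift the number beyond the scatter. Compound 2 differs from the others in more than one place, so its lower number cannot be tied to any single group.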